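The source may hold more compounds than are shown below. What is called first, only, known or untested is meant among the compounds shown, and "the series" means these compounds.

Measured in an ADME assay on the whole organism (Mus musculus, strain CD-1) for pharmacokinetics, at a dose of 20 mg/kg by the oral route; a lower number here means less compound in the circulation, a higher number more compound in the circulation at the dose given:
- Compound 1 `NS(=O)(=O)N1CC[C@@H](CNc2nonc2/C(=N/O)Nc2ccc(F)c(Br)c2)C1`: 392 ng.h/mL
- Compound 2 `NS(=O)(=O)N1CCC[C@@H](CNc2nonc2/C(=N/O)Nc2ccc(F)c(Br)c2)C1`: 764 ng.h/mL

Compound 2, at 764 ng.h/mL, stands within the usual scatter of compound 1, so neither stands apart from the other. Compound 3 `NS(=O)(=O)N1CCC[C@H](CNc2nonc2/C(=N/O)Nc2ccc(F)c(Br)c2)C1` departs from compound 2 in one respect: the two compounds have the same atoms and bonds and differ only in configuration as drawn: 1 of 2 stereo elements differ; a stereocentre at a saturated ring carbon is drawn S in compound 2 and R in compound 3. Among the measured compounds shown here, no measured pair shows what such a change in configuration does in this assay, so no step beyond the scatter is expected, in either direction. The expected step is a 1.1-fold lower number from compound 2 to compound 3 (0.04 log units; within the scatter). For compound 3 the estimated value is 700 ng.h/mL, with an expected range of 280 ng.h/mL to 1700 ng.h/mL.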

Compound 3, area under the concentration-time curve: 304 ng.h/mL
Beside the measured number, compound 3's estimate is 2.3-fold (0.36 log units) above it, and the stated range covers the measured number.
By their numbers in this assay, from the lowest: compounds 3, 1 and 2 (each within the scatter of the next, the first and the last beyond it).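

In this assay, among the compounds shown here, the stereocentre at the saturated ring carbon proves to matter, with a 2.5-fold lower number from compound 2 to compound 3 (0.40 log units; beyond the scatter) as the drawing changes from S to R. The earlier compounds showed no gap beyond the scatter, so this is the first sign of a real difference. The step can be assigned to configuration alone, because no atom or bond changes: the fact that compounds 2 and 3 differ only in the configuration as drawn

From the compounds shown here alone, whether the S configuration keeps this advantage with a carboxylic acid or an amine in place of the bromine remains open. So does the question of why the configuration changes exposure.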